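Replacing the 1,3-benzoxazol-2-yl group of compound 3

The source may report more compounds than this note shows. Statements on the series, on what has been measured and on what is new or still open speak of the compounds shown alone.

Compound 1 `COc1ccc(-c2cnc(NC(=O)CCCCCCNC(=O)C(O)(O)C(F)(F)F)s2)cc1`: 930 nM
Compound 2 `CCOc1ccc(-c2cnc(NC(=O)CCCCCCNC(=O)C(O)(O)C(F)(F)F)s2)cc1`: 4050 nM
Compound 3 `O=C(CCCCCCNC(=O)C(O)(O)C(F)(F)F)Nc1nc2ccccc2o1`: 3450 nM
Compound 4 `COc1ccccc1NC(=O)CCCCCCNC(=O)C(O)(O)C(F)(F)F`: not yet measured

In a functional assay on HCT-116 cells (Homo sapiens) for inhibition, read by colorimetric assay, with a stated time of 3 days (a lower number here means a stronger inhibitor, a higher number a weaker inhibitor), compound 3 gives 3450 nM, within the scatter of compound 2 and a higher number than compound 1. Compound 4 carries 2-methoxyphenyl in place of 1,3-benzoxazol-2-yl on an amide-type nitrogen. For the measured compounds named here, the only measured step, a 4.4-fold higher number from compound 1 to compound 2 (0.64 log units; beyond the scatter), was modest but concerns a different change, a methyl in place of hydrogen, so it bears only indirectly. Going by the values given here, no measured step covers this replacement, and no direction can be read from the data. The expected outcome, with no change beyond the scatter, is a 1.2-fold lower number from compound 3 to compound 4 (0.06 log units; within the scatter). Compound 4 is estimated at 3000 nM, with an expected range of 1000 nM to 9000 nM.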

Compound 4, half-maximal inhibitory concentration: 10100 nM
Compound 4: the middle estimate sits 3.4-fold (0.53 log units) below what was measured; the whole stated range lies below it.
By their numbers in this assay, from the lowest: compound 1; then compounds 3 and 2 (each within the scatter of the next); then compound 4.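

In this assay, for the compounds shown here, 2-methoxyphenyl in place of 1,3-benzoxazol-2-yl on the amide-type nitrogen gives a 2.9-fold higher number from compound 3 to compound 4 (0.47 log units; beyond the scatter), so the number does respond to this replacement, which the earlier compounds could not show. The step is modest, and it comes with the loss of the five-membered aromatic ring and one hydrogen-bond acceptor. No evidence available here ties the step to either difference or to any other cause. The compounds shown leave open how a plain phenyl or a pyridine ring would fare on this nitrogen. They also leave open whether the step would hold on a longer chain.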